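Methyl in Place of Trifluoromethyl: Expectation for Compound 3

This account rests on a few compounds, and the source may have more. Where it says the series, first, only, none or still open, it means among the compounds named here.

Compound 2 `CN(C)C(=O)c1cc2cnc(Nc3ccc(NC(=O)C4(C(=O)Nc5cccc(C(F)(F)F)c5)CC4)cc3)nc2n1C1CCCC1` stands highest of the two compounds measured in a functional assay on T47D cells (Homo sapiens) for inhibition, read by CCK-8 assay, with a stated time of 72 h, tested at 10 uM; a higher number here means more inhibition of growth at the concentration tested, a lower number less inhibition of growth: compound 2 gives 92.7%. Within the data shown here, compound 1 `CN(C)C(=O)c1cc2cnc(Nc3ccc(NC(=O)C4(C(=O)Nc5ccc(F)cc5)CC4)cc3F)nc2n1C1CCCC1` gives 67.9% in this assay, a number lower by a margin beyond the scatter, though it differs from compound 2 in more than one place and no single step connects the two. Compound 3 `Cc1cccc(NC(=O)C2(C(=O)Nc3ccc(Nc4ncc5cc(C(=O)N(C)C)n(C6CCCC6)c5n4)cc3)CC2)c1` has not been measured. It differs from compound 2 by methyl in place of trifluoromethyl on an aromatic carbon. Among the measured compounds shown here, no measured pair shows this change, so its step in this assay is unknown; a small loss or no change beyond the scatter is expected, a number 8.7 percentage points lower from compound 2 to compound 3 (within the scatter). Compound 3 is accordingly expected to give 84% in this assay, within 65% to 96%.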

Compound 3, percent growth inhibition at one concentration: 95.3%
Compound 3: the middle estimate sits 11.3 percentage points below what was measured, within the range that was stated.
By their numbers in this assay, from the lowest: compound 1; then compounds 2 and 3 (each within the scatter of the next).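

In this assay, methyl in place of trifluoromethyl on this aromatic carbon gives a number 2.6 percentage points higher from compound 2 to compound 3 (within the scatter), the first step read at this position in a pair differing in one place. The 3-methylphenyl group of compound 3 therefore serves as well as the 3-(trifluoromethyl)phenyl group of compound 2, so the three fluorine atoms are not required for the growth inhibition seen at the concentration tested. Nothing given here explains why the two groups read alike.

As far as these compounds go, whether an amine, a carboxylic acid or a longer chain at this place would keep the number remains open. So does whether the same change would read alike on the background of compound 1.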